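Dichloroacetamide biaryls: trifluoromethyl for chloro, compound 3 estimate

This account rests on a few compounds, and the source may have more. Where it says the series, first, only, none or still open, it means among the compounds named here.

Compound 1 `O=C(Nc1cccc(-c2ccc(Cl)cc2)c1)C(Cl)Cl` holds the higher of the two numbers measured in a functional assay on KB 3-1 cells (Homo sapiens) for cytotoxicity, read by MTT assay, with a stated time of 68 h; a lower number here means a stronger inhibitor, a higher number a weaker inhibitor: compound 1 gives 38200 nM. For the measured compounds named here, compound 2 `COc1ccc(-c2cc(NC(=O)C(Cl)Cl)cc(-c3ccc(OC)c(F)c3)c2)cc1F` gives 2940 nM, a gap beyond the scatter, but no single-change step connects the two. Compound 3 `O=C(Nc1cccc(-c2ccc(C(F)(F)F)cc2)c1)C(Cl)Cl` differs from compound 1 by trifluoromethyl in place of chloro on an aromatic carbon. Going by the values given here, no measured step of this kind exists in the set, so the change is expected to move this assay little, if at all beyond the scatter, in either direction. Compound 3 is thus estimated at 30000 nM, with range 10000 nM to 90000 nM. The expected step is a 1.3-fold lower number from compound 1 to compound 3 (0.10 log units; within the scatter).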

Compound 3, half-maximal inhibitory concentration: > 50000 nM
Compound 3: only a limit was reported; the forecaster's own chance of this, stated with the estimate: 10%; middle value at least 1.6-fold (0.22 log units) from the limit.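

In this assay compound 3 gives > 50000 nM, which is a limit and not a number. Trifluoromethyl in place of chloro, para to a large group, is the first single-change step at this position, and it gives an at least 1.3-fold higher number from compound 1 to compound 3 (0.11 log units; that floor lies within the scatter). It therefore brings no lower number than chloro, though its true size cannot be read: the limit of > 50000 nM in this assay, at which 1 of the 3 values shown sits.

From the compounds shown here alone, whether an amine or a carboxylic acid on this carbon would lower the number remains open. So does the effect of this change on the core of compound 2.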